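The source may hold more compounds than are shown below. What is called first, only, known or untested is meant among the compounds shown, and "the series" means these compounds.

In an ADME assay on BaF3 cells (Mus musculus) for cytotoxicity, read by CellTiter-Glo and CCK-8 assay, with a stated time of 72 h (a lower number here means a stronger inhibitor of growth, a higher number a weaker inhibitor of growth), compound 1 (`Cc1ccc(NC(=O)c2ccc(CN(CCN(C)C)C(=O)C3CC3)cc2)cc1Nc1nccc(-c2cccnc2)n1`) gives > 10000 nM, which is a limit of the assay. Compound 2 (`Cc1ccc(NC(=O)c2ccc(CN(CCN(C)C)C(=O)CN(C)C)cc2)cc1Nc1nccc(-c2cccnc2)n1`) gives > 10000 nM, also a limit, so it has no numerical position. Compound 3 (`Cc1ccc(NC(=O)c2ccc(CN(CCN(C)C)C(=O)c3cccs3)cc2)cc1Nc1nccc(-c2cccnc2)n1`) has thiophen-2-yl in place of (dimethylamino)methyl on a carbonyl carbon. For the measured compounds named here, the one measured step bearing on this change is a step that the two limits leave unreadable from compound 1 to compound 2, and the only evidence is the limit of > 10000 nM in this assay, at which 2 of the 2 values shown sit. The expected a number no higher from compound 2 to compound 3 (the limit leaves the size open) in this assay is therefore none beyond the scatter, with no direction favoured. Compound 3 is estimated at 10000 nM, within a range of 4000 nM to 30000 nM.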

Compound 3, concentration for 50% growth inhibition: > 10000 nM
Compound 3 gave a limit, no number; the forecaster's own chance of this, stated with the estimate: 75%; the middle value lies on the limit itself.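

For the compounds shown here, compound 1, compound 2 and compound 3 all give a limit rather than a number, so no step among them can be read: the limit of > 10000 nM in this assay, at which 3 of the 3 values shown sit. Going by these compounds, whether cyclopropyl, (dimethylamino)methyl or thiophen-2-yl on the carbonyl carbon makes any difference remains open.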